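A few compounds are considered here, and "the series" means these few. Any claim that something is new, unique, unknown or untested is made for them only; others in the source may bear on it.

Measured compounds:
compound 1, `COc1cc(OC)c(/C=C/S(=O)(=O)Cc2ccc(C#N)cc2)c(OC)c1` — 15000 nM
compound 2, `COc1ccc(CS(=O)(=O)/C=C/c2ccc(F)cc2)cc1` — 2500 nM

In a functional assay on H157 cells (Homo sapiens) for antiproliferative activity, read by trypan blue exclusion (a higher number here means a weaker inhibitor, a lower number a stronger inhibitor), compound 1 gives the higher of the two numbers; compound 2, in this assay at 2500 nM, sits well below it, beyond the usual scatter. The next compound, compound 3 `COc1ccc(CS(=O)(=O)/C=C/c2c(OC)cc(OC)cc2OC)cc1`, is not yet measured. It differs from compound 1 by methoxy in place of cyano on an aromatic carbon. Compound 2 also carries a methoxy on its benzyl ring and gives the lower number, so the step from compound 1 to compound 3 is expected to move downward, likely beyond the scatter, by about a 3.0-fold lower number from compound 1 to compound 3 (0.48 log units; beyond the scatter). For compound 3 the estimate is 5000 nM, with a range of 1500 nM to 15000 nM.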

Compound 3, half-maximal inhibitory concentration: 30 nM
Estimate against measurement, compound 3: 170-fold (2.22 log units) above, outside the stated range (below it).
By their numbers in this assay, from the lowest: compound 3; then compound 2; then compound 1.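

Measured in this assay the change of cyano to methoxy, para to a large group, gives a 500-fold lower number from compound 1 to compound 3 (2.70 log units; beyond the scatter) and so shows that this single position strongly governs the number. The two groups have the same heavy-atom count and one hydrogen-bond acceptor each, so those counts cannot separate them. Nothing measured here explains the size of this step.

From the compounds shown here alone, whether methoxy is the best group at this carbon stays open, as a hydroxyl, an amine or a plain hydrogen there could read differently. Going by these compounds, whether the step would carry over to another core also remains open.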